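Compound 4 in human liver microsome stability: working notes

The source may hold more compounds than are shown below. What is called first, only, known or untested is meant among the compounds shown, and "the series" means these compounds.

compound 1 `CC(C)[C@@H](CO)n1cc(C(=O)O)c(=O)c2cc(Cc3cccc(Cl)c3F)cnc21`: 99%
compound 2 `CCOc1nc2c(cc1Cc1cccc(Cl)c1F)c(=O)c(C(=O)O)cn2[C@H](CO)C(C)(C)C`: 84%
compound 3 `COc1nc2c(cc1NCc1cccc(Cl)c1F)c(=O)c(C(=O)O)cn2[C@H](CO)C(C)C`: "not determined" (no result reported)

In an ADME assay on microsomes from liver (Homo sapiens) for metabolic stability, with a stated time of 30 min (a higher number here means that more of the compound is left, a lower number that less of the compound is left), compound 1 gives 99% and compound 2 gives 84% on the same read-out. Both values sit high on the scale, although these two compounds differ in more than one place. Compound 3 has no number: its entry reads "not determined" (no result reported) and so offers no baseline for comparison.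

The next structure is compound 4 `COc1nc2c(cc1NCc1c(F)cc(F)cc1F)c(=O)c(C(=O)O)cn2[C@H](CO)C(C)C`, which differs from compound 3 in one place (2,4,6-trifluorophenyl in place of 3-chloro-2-fluorophenyl on a saturated chain carbon bound to a nitrogen on an aromatic ring). It carries 2,4,6-trifluorophenyl in place of 3-chloro-2-fluorophenyl on a saturated chain carbon bound to a nitrogen on an aromatic ring. Among the compounds with values here, the series holds no measured pair that differs in one place, so this change has no direct precedent. No step beyond the usual scatter is expected, and no direction is favoured. With no value for compound 3, the expectation rests only on the level set by compound 1 at 99% and compound 2 at 84%, and the range is kept wide for that reason. Compound 4 is expected in this assay to read 85% with an estimated range from 65% to 100% (an expectation, not yet a measurement).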

Compound 4, percent of the compound remaining: 82%
For compound 4 the middle estimate is 3 percentage points above the measured one; measured number inside the range.
By their numbers in this assay, from the lowest: compounds 4 and 2 (each within the scatter of the next); then compound 1.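

No new step can be read from compound 3 and compound 4: compound 3 carries no number to set against compound 4. The compounds shown leave open what 2,4,6-trifluorophenyl in place of 3-chloro-2-fluorophenyl does by itself to the percent of compound remaining. No supporting data bear on this result.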